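Amide aryl variation on the shared core

The source may report more compounds than this note shows. Statements on the series, on what has been measured and on what is new or still open speak of the compounds shown alone.

Compound 1 `COc1ccccc1C(=O)Nc1cccc(-c2oc3cc(-c4ccc(F)cc4)ccc3c(=O)c2O)c1` and compound 2 `COc1cc(OC)cc(C(=O)Nc2cccc(-c3oc4cc(-c5ccc(F)cc5)ccc4c(=O)c3O)c2)c1` share one core and differ only in the aryl group attached to the amide carbonyl. In a functional assay on MDA-MB-231 cells (Homo sapiens) for antiproliferative activity, read by CCK-8 assay, with a stated time of 72 h (a higher number here means a weaker inhibitor, a lower number a stronger inhibitor), compound 1 gives 5110 nM, and in this assay compound 2 gives 4040 nM. The step of a 1.3-fold lower number from compound 1 to compound 2 (0.10 log units; within the scatter) stays within the scatter, so the two numbers cannot be ordered; compound 2 carries the lower of the two numbers shown, with compound 1 inside the scatter of it.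

Compound 3 `O=C(Nc1cccc(-c2oc3cc(-c4ccc(F)cc4)ccc3c(=O)c2O)c1)c1cc(F)cc(F)c1` is reached from compound 2 by 3,5-difluorophenyl in place of 3,5-dimethoxyphenyl on a carbonyl carbon. Among the measured compounds shown here, no measured step exchanges methoxy for fluorine on this phenyl ring. For the measured compounds named here, the only step available, which replaces 2-methoxyphenyl by 3,5-dimethoxyphenyl on the same carbonyl carbon, was within the scatter. On that basis no shift beyond the scatter is expected in this assay for compound 3, which is estimated at 4000 nM (range 1500 nM to 11000 nM). The expected step is a 1.0-fold lower number from compound 2 to compound 3 (0.00 log units; within the scatter).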

Compound 3, half-maximal inhibitory concentration: 2440 nM
Estimate against measurement, compound 3: 1.6-fold (0.21 log units) above; low and high end bracket the measured number.
By their numbers in this assay, from the lowest: compounds 3, 2 and 1 (each within the scatter of the next, the first and the last beyond it).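

In this assay, the aryl group on the carbonyl carbon now gives the first separation in this set: 3,5-difluorophenyl in place of 2-methoxyphenyl produces a modest step (a 2.1-fold lower number from compound 1 to compound 3 (0.32 log units; beyond the scatter)). The change from 3,5-dimethoxyphenyl to 3,5-difluorophenyl does not separate its pair (a 1.7-fold lower number from compound 2 to compound 3 (0.22 log units; within the scatter)), so compound 2 and compound 3 cannot be ordered, and only the two ends of the set stand apart. No measurement is at hand that bears on the origin of either step.

All three aryl groups shown are substituted phenyl rings, so the response of this position to an unsubstituted phenyl, a pyridyl ring or a trifluoromethyl-bearing phenyl remains open. Also open, on these data alone, is whether a basic amine or a carboxylic acid on this ring would move the number beyond the scatter.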